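Changing one sulfonyl group on a well-tolerated compound

A few compounds are considered here, and "the series" means these few. Any claim that something is new, unique, unknown or untested is made for them only; others in the source may bear on it.

In an ADME assay on MT4 cells (Homo sapiens) for cytotoxicity, read by MTT assay, with a stated time of 5 days (a lower number here means that less compound is tolerated, a higher number that more compound is tolerated), compound 1 (`Cc1cc(C)cc(S(=O)(=O)c2c(C(=O)NC3CNC3)[nH]c3ccc(Cl)cc23)c1`) gives 37300 nM, while compound 2 (`Cc1cc(C)cc(S(=O)(=O)c2c(C(=O)NS(=O)(=O)C(F)(F)F)[nH]c3ccc(Cl)cc23)c1`) gives 141000 nM, the higher of the two numbers. The next structure, compound 3 (`Cc1cc(C)cc(S(=O)(=O)c2c(C(=O)NS(=O)(=O)c3ccccc3)[nH]c3ccc(Cl)cc23)c1`), keeps the shared core and has phenyl in place of trifluoromethyl on a sulfonyl sulfur. For the measured compounds named here, only one measured step bears on this change: a 3.8-fold higher number from compound 1 to compound 2 (0.58 log units; beyond the scatter). That modest step replaced azetidin-3-yl with (trifluoromethyl)sulfonyl on an amide-type nitrogen, so it altered the same part of the molecule but did not make this exact swap. It is therefore only a rough guide to size. With so little data, a modest fall of similar size is expected, a 2.0-fold lower number from compound 2 to compound 3 (0.30 log units; within the scatter). For compound 3, the estimated value is 70000 nM, with an expected range of 25000 nM to 200000 nM.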

Compound 3, half-maximal cytotoxic concentration: 167000 nM
Compound 3: the middle estimate sits 2.4-fold (0.38 log units) below what was measured; low and high end bracket the measured number.
By their numbers in this assay, from the lowest: compound 1; then compounds 2 and 3 (each within the scatter of the next).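

In this assay, putting phenyl in place of trifluoromethyl on the sulfonyl sulfur gives a 1.2-fold higher number from compound 2 to compound 3 (0.07 log units; within the scatter), so this position does not separate the two groups, although only phenyl brings a six-membered aromatic ring. The change from azetidin-3-yl to phenylsulfonyl on the amide-type nitrogen gives a 4.5-fold higher number from compound 1 to compound 3 (0.65 log units; beyond the scatter), which means the gap from compound 1 seen with (trifluoromethyl)sulfonyl also appears with a quite different group on the sulfur. Nothing measured here offers a reason for either result.

From the compounds shown here alone, it remains open whether a methyl, a longer alkyl chain or a phenyl ring carrying an amine on the sulfonyl sulfur would also stay level with compound 2 and compound 3. An acetyl group on the amide-type nitrogen would test whether the sulfonyl itself is needed at all.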